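This account rests on a few compounds, and the source may have more. Where it says the series, first, only, none or still open, it means among the compounds named here.

Of the compounds shown here, three have been measured so far in a functional assay on DU-145 cells (Homo sapiens) for inhibition, read by trypan blue exclusion, with a stated time of 96 h; a higher number here means a weaker inhibitor of growth, a lower number a stronger inhibitor of growth. Compound 1 (`Cc1ccc(S(=O)(=O)/C(=C/c2ccc(C)s2)C(=O)c2ccc(Br)cc2)cc1`) gives 25000 nM and compound 2 (`O=C(/C(=C\c1ccc(Cl)cc1)SCc1ccc(Cl)cc1)c1ccccc1Cl`) gives 30000 nM while compound 3 (`Cc1cc(C)cc(/C=C(/SCc2ccc(Br)cc2)C(=O)c2ccccc2Cl)c1`) gives 10000 nM as the lowest number of the three. Compound 3 is therefore the strongest inhibitor of this small set, and its gaps to both of the others lie beyond the usual scatter. No two of these compounds differ in only one place, so the data hold no direct measure of what a single change does.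

Compound 4 (`O=C(/C(=C\c1ccc(Cl)cc1)SCc1ccc(Br)cc1)c1ccccc1Cl`) has not yet been measured. It differs from compound 3 in one group (4-chlorophenyl in place of 3,5-dimethylphenyl on a double-bonded chain carbon bound to a double-bonded chain carbon) with 4-chlorophenyl in place of 3,5-dimethylphenyl on a double-bonded chain carbon bound to a double-bonded chain carbon. For the measured compounds named here, the one available hint is compound 2, which also carries 4-chlorophenyl on such a carbon and gives 30000 nM in this assay while compound 3 gives 10000 nM there. This is only a hint, so a modest loss of strength is expected, close to the edge of the scatter. The expected change is a 2.0-fold higher number from compound 3 to compound 4 (0.30 log units; within the scatter) toward a higher number. For compound 4 the estimated value is 20000 nM with an expected range from 8000 nM to 45000 nM for the measurement.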

Compound 4, concentration for 50% growth inhibition: 25000 nM
For compound 4 the middle estimate is 1.3-fold (0.10 log units) below the measured one; the range from low to high includes it.
By their numbers in this assay, from the lowest: compound 3; then compounds 1, 4 and 2 (each within the scatter of the next).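

Replacing 3,5-dimethylphenyl with 4-chlorophenyl on a double-bonded chain carbon bound to a double-bonded chain carbon gives the first direct measure of a single change at this position in this assay. It produces a 2.5-fold higher number from compound 3 to compound 4 (0.40 log units; beyond the scatter), so compound 4 is a weaker inhibitor of growth than compound 3, though the step is modest. At the other changed place, bromo in place of chloro on an aromatic carbon gives a 1.2-fold lower number from compound 2 to compound 4 (0.08 log units; within the scatter), so compound 2 and compound 4 cannot be told apart in this assay, and no evidence is available to explain either step.

The step from compound 3 to compound 4 changes both the substituents and their places on the ring at once, so it cannot show whether losing the two methyl groups or gaining the chlorine matters more. A plain phenyl or a 3,5-dichlorophenyl group at this position would help separate those two parts of the change, while an amine on the ring would test a quite different kind of substituent there.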